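Replacing nitro with hydrogen in compound 1

The compounds below may be only part of what the source reports. "The series", "measured", "known", "first", "only" and "open" are said of these compounds alone.

- compound 1 `Nc1ccccc1NC(=O)c1ccc(COc2ccc([N+](=O)[O-])cc2)cc1`: > 32000 nM
- compound 2 `O=C(/C=C/c1ccc(CN2CCc3ccccc32)cc1)NO`: "not determined" (no result reported)
- compound 3 `Nc1ccccc1NC(=O)/C=C/c1ccc(COc2ccccc2)cc1`: > 32000 nM

All three were taken into a functional assay on MGC-803 cells (Homo sapiens) for antiproliferative activity, read by CCK-8 assay, with a stated time of 72 h; a higher number here means a weaker inhibitor, a lower number a stronger inhibitor. There, compound 1 stands at > 32000 nM, which is a limit of the assay and not a number. Compound 3 gives > 32000 nM, and this too is a limit. For compound 2 the entry reads "not determined" (no result reported). Among the measured compounds shown here, the picture so far is therefore (the limit of > 32000 nM in this assay, at which 2 of the 3 values shown sit), and no compound has yet given a true number.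

Compound 4 `Nc1ccccc1NC(=O)c1ccc(COc2ccccc2)cc1` has not yet been measured. It derives from compound 1 by one change, hydrogen in place of nitro on an aromatic carbon, para to a large group: hydrogen in place of nitro on an aromatic carbon. The same difference can be read as 4-nitrophenyl to phenyl.

For the measured compounds named here, no measured step shows what this change does in this assay, so the expectation is for no step beyond the scatter, with neither direction favoured. That expectation rests on compound 1 at > 32000 nM. It rests equally on compound 3 at > 32000 nM. The expected size of the change is a number no higher from compound 1 to compound 4 (the limit leaves the size open). A report of only a limit is also expected to be the likeliest outcome. For compound 4 the estimated value is 32000 nM, with an expected range from 12000 nM to 64000 nM.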

Compound 4, half-maximal inhibitory concentration: 5670 nM
For compound 4 the middle estimate is 5.6-fold (0.75 log units) above the measured one; measured number below the stated range.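

In this assay compound 4 gives 5670 nM, the first true number among the compounds shown, so the shared core can give a measurable result once this position carries hydrogen. Hydrogen in place of nitro, on an aromatic carbon para to a large group, brings an at least 5.6-fold lower number from compound 1 to compound 4 (0.75 log units; beyond the scatter), a step beyond the scatter, which shows that this position is not indifferent to the change and that the 4-nitrophenyl compound is the weaker of the pair. As far as these compounds go, compound 1 gives > 32000 nM, which is a limit of the assay and not a number, so the step printed is only a floor and its full size remains unknown.

From the compounds shown here alone, whether nitro is specifically the unfavourable group, or whether anything larger than hydrogen at this place would give the same result, remains open, and an amine, a methoxy group or a chlorine atom there could fall on either side of the pair. Only one step can be read so far, and much of the series still gives no number: the limit of > 32000 nM in this assay, at which 2 of the 4 values shown sit.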